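Swapping a Nitro Group for Two Fluorines

The source may report more compounds than this note shows. Statements on the series, on what has been measured and on what is new or still open speak of the compounds shown alone.

Of the compounds shown here, two share one core and have been tested in a functional assay on SW 1116 cells (Homo sapiens) for antiproliferative activity, read by MTT assay, with a stated time of 24 h; on this read-out lower numbers stand for stronger inhibition and higher numbers for weaker inhibition. Compound 1 `O=[N+]([O-])c1ccccc1CSc1nnc(-c2ccc3c(c2)OCCO3)n1-c1ccccc1` gives 8300 nM in this assay, and compound 2 `Fc1ccccc1CSc1nnc(-c2ccc3c(c2)OCCO3)n1-c1ccccc1` gives 13600 nM. The step of a 1.6-fold higher number from compound 1 to compound 2 (0.21 log units; within the scatter) is the only one measured, and it separates these two compounds by no more than the usual scatter. Compound 3 `Fc1ccc(CSc2nnc(-c3ccc4c(c3)OCCO4)n2-c2ccccc2)c(F)c1` differs from compound 1 by 2,4-difluorophenyl in place of 2-nitrophenyl on a saturated chain carbon bound to a sulfur. Going by the values given here, that single step is the only guide, so compound 3 is expected to move by a 1.4-fold higher number from compound 1 to compound 3 (0.16 log units; within the scatter) at most, that is, nothing beyond the scatter. Compound 3 is therefore estimated at 12000 nM in this assay, within a range of 5000 nM to 30000 nM.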

Compound 3, half-maximal inhibitory concentration: 7830 nM
For compound 3 the middle estimate is 1.5-fold (0.19 log units) above the measured one; the range from low to high includes it.
By their numbers in this assay, from the lowest: compounds 3, 1 and 2 (each within the scatter of the next).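

In this assay the change goes further than before, yet 2,4-difluorobenzyl in place of 2-nitrobenzyl gives a 1.1-fold lower number from compound 1 to compound 3 (0.03 log units; within the scatter), so even replacing the whole 2-nitrophenyl group leaves no readable difference. Fluoro in place of hydrogen on an aromatic carbon gives a 1.7-fold lower number from compound 2 to compound 3 (0.24 log units; within the scatter), so this added fluorine also shows no readable effect. Nothing measured here explains why these numbers stay so close. As far as these compounds go, whether an amine or a carboxylic acid on this ring, or a longer chain at this place, would move the number beyond the scatter remains open.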